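Dichlorophenyl urea series: ring swap on the anilino nitrogen

This account rests on a few compounds, and the source may have more. Where it says the series, first, only, none or still open, it means among the compounds named here.

Compound 1 `Cc1ccc(Nc2cc(NC(=O)Nc3c(Cl)cccc3Cl)ncn2)cc1F` stands highest of the two measured compounds in a functional assay on HCC827 cells (Homo sapiens) for inhibition, read by MTT assay, with a stated time of 48 h, tested at 10 uM (a higher number here means more inhibition at the concentration tested (going by the name of the read-out), a lower number less inhibition), giving 85.3%. Among the measured compounds shown here, compound 2 `COc1cc(NC(=O)Nc2cc(Nc3cccc(C(C)(C)C)c3)ncn2)cc(OC)c1`, the only other measured compound, gives 48.7% in this assay, a gap beyond the usual scatter. Compound 3 `CCc1ccc(Nc2cc(NC(=O)Nc3c(Cl)cccc3Cl)ncn2)cc1` differs from compound 1 in one place: 4-ethylphenyl in place of 3-fluoro-4-methylphenyl on a nitrogen on an aromatic ring. For the measured compounds named here, no measured pair shows this change, so the step in this assay from compound 1 to compound 3 is expected to be small, either none beyond the scatter or a modest drop, as an estimated step of a number 7.3 percentage points lower from compound 1 to compound 3 (within the scatter). For compound 3 the expected inhibition in this assay is 78%, in the range 55% to 92%.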

Compound 3, a percentage reported as inhibition, at one concentration (the size of the read-out at that concentration, not a potency): 58%
Compound 3: the middle estimate sits 20 percentage points above what was measured; the range from low to high includes it.
By their numbers in this assay, from the lowest: compounds 2 and 3 (each within the scatter of the next); then compound 1.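

This position on the nitrogen on an aromatic ring is not indifferent to the aryl group: in this assay, 4-ethylphenyl in place of 3-fluoro-4-methylphenyl gives a number 27.3 percentage points lower from compound 1 to compound 3 (beyond the scatter), although both groups have the same heavy-atom count and a single carbon-only aromatic ring. No measurement explains this loss of inhibition.

The change removes the fluorine and replaces methyl with ethyl at once, so the two contributions cannot be separated. From the compounds shown here alone, a 4-methylphenyl or 3-fluoro-4-ethylphenyl group would separate them, while a morpholine or carboxylic acid on the ring remains open.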